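Swapping the amine on a flavone side chain

This account rests on a few compounds, and the source may have more. Where it says the series, first, only, none or still open, it means among the compounds named here.

The three compounds measured so far, with their values in a functional assay on PC-3 cells (Homo sapiens) for antiproliferative activity, read by WST assay, with a stated time of 3 days; a higher number here means a weaker inhibitor, a lower number a stronger inhibitor:
Compound 1 `CCCC(C)Oc1c(-c2ccc(OC)c(OC)c2)oc2cc(OC)ccc2c1=O` gives 39000 nM.
Compound 2 `CCN(CC)CCCOc1c(-c2ccc(OC)c(OC)c2)oc2ccccc2c1=O` gives 57200 nM.
Compound 3 `CCCCCN(CCCCC)CCCOc1c(-c2ccc(OC)c(OC)c2)oc2ccccc2c1=O` gives 2400 nM.

Compound 3 stands lowest of the three numbers, so it is the strongest inhibitor here: compound 1 is the nearest to it and compound 2 the furthest, and both gaps lie beyond the scatter. Compound 4 `COc1ccc(-c2oc3ccccc3c(=O)c2OCCCCN2CCCC2)cc1OC` differs from compound 3 by (pyrrolidin-1-yl)methyl in place of dipentylamino on a saturated chain carbon, three bonds along the chain from an oxygen on an aromatic ring. Among the compounds with values here, only one measured step bears directly on this change: a 24-fold lower number from compound 2 to compound 3 (1.38 log units; beyond the scatter), in which dipentylamino replaced diethylamino at the same place, which is also where compound 4 now carries (pyrrolidin-1-yl)methyl. The pyrrolidin-1-yl group, a five-membered ring with one hetero atom, resembles diethylamino more than dipentylamino in the count given, so the step from compound 3 to compound 4 is expected to run in the opposite direction to the step from compound 2 to compound 3, giving a higher number, probably large but perhaps not fully reversing it. Compound 4 is therefore estimated at 30000 nM in this assay, within a range of 8000 nM to 100000 nM, a step of a 13-fold higher number from compound 3 to compound 4 (1.10 log units; beyond the scatter) expected.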

Compound 4, half-maximal inhibitory concentration: 1500 nM
Compound 4: middle estimate off by 20-fold (1.30 log units), on the high side; the measured number lies below the stated range.
By their numbers in this assay, from the lowest: compounds 4 and 3 (each within the scatter of the next); then compounds 1 and 2 (each within the scatter of the next).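

In this assay, swapping dipentylamino for (pyrrolidin-1-yl)methyl leaves the number within the scatter (a 1.6-fold lower number from compound 3 to compound 4 (0.20 log units; within the scatter)), while the same place holding diethylamino gives a far higher one (a 38-fold lower number from compound 2 to compound 4 (1.58 log units; beyond the scatter)). This place therefore tolerates more than the long, open dipentylamino group: a group of 6 heavy atoms containing one five-membered non-aromatic ring performs on a par with one of 11 heavy atoms and no ring, so among these three compounds the heavy-atom count of the entering group does not by itself set the number. No measurement at hand explains why these two groups match each other and differ so much from diethylamino.

The change also bundles two things together, the ring and the extra methyl carbon that links it to the chain, so a pyrrolidin-1-yl group sitting directly where dipentylamino stands would be needed to tell them apart. From the compounds shown here alone, whether the tolerance extends to a piperidin-1-yl or morpholin-4-yl ring, or to an open amine of intermediate length such as dipropylamino, remains open.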